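Swapping a chloro for trifluoromethyl on the urea aryl

The source may hold more compounds than are shown below. What is called first, only, known or untested is meant among the compounds shown, and "the series" means these compounds.

Compound 1 `COc1cc(-c2nn(-c3cccc(NC(=O)Nc4ccc(Cl)c(Cl)c4)c3)cc2-c2ccncc2)ccc1Cl` belongs to a small set of diaryl ureas sharing one core. In a functional assay on OVCAR-3 cells (Homo sapiens) for inhibition, read by sulforhodamine B assay, with a stated time of 48 h (on this read-out higher numbers stand for weaker inhibition of growth and lower numbers for stronger inhibition of growth), compound 1 gives 697 nM. Compound 2 `O=C(Nc1cccc(-n2cc(-c3ccncc3)c(-c3ccc(Cl)c(O)c3)n2)c1)Nc1ccc(Cl)c(Cl)c1` gives 1050 nM in this assay, and compound 3 `O=C(Nc1cccc(-n2cc(-c3ccncc3)c(-c3ccc(Cl)c(O)c3)n2)c1)Nc1cc(C(F)(F)F)cc(C(F)(F)F)c1` gives 395 nM; the gaps from compound 1 to both of these lie within the usual scatter, so compound 1 sits among them without any clear separation.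

Compound 4 `COc1cc(-c2nn(-c3cccc(NC(=O)Nc4ccc(Cl)c(C(F)(F)F)c4)c3)cc2-c2ccncc2)ccc1Cl` differs from compound 1 by trifluoromethyl in place of chloro on an aromatic carbon. Going by the values given here, the only measured step that touches a single change, a 1.5-fold higher number from compound 1 to compound 2 (0.18 log units; within the scatter), concerns the oxygen substituent on the other end of the core and says nothing about the urea aryl. Compounds 2 and 3 carry different urea aryls, but that comparison involves more than one change, and their values alone do not show a clear trend.

Among the compounds with values here, with no direct precedent, a step of modest size is expected: a 1.3-fold lower number from compound 1 to compound 4 (0.10 log units; within the scatter). Compound 4 is therefore estimated at 550 nM, with a range from 250 nM to 1300 nM.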

Compound 4, concentration for 50% growth inhibition: 889 nM
The estimate for compound 4 lay 1.6-fold (0.21 log units) below the measured number; low and high end bracket the measured number.
By their numbers in this assay, from the lowest: compounds 3, 1, 4 and 2 (each within the scatter of the next, the first and the last beyond it).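

On the urea aryl, the 3,4-dichlorophenyl of compound 1 gives way to the 4-chloro-3-(trifluoromethyl)phenyl of compound 4 in this assay with a 1.3-fold higher number from compound 1 to compound 4 (0.11 log units; within the scatter). Going by these compounds alone, this is the first single-change step at this end of the molecule, and it shows that trifluoromethyl, with 4 heavy atoms where chloro has 1, leaves the read-out inside the usual scatter at this place. No measurement is at hand that would explain this result.

On these data alone, whether the same exchange would also stay inside the scatter with the hydroxy group of compound 2 in place of the methoxy group remains open. So does the question of whether a nitrile, an amine or a carboxylic acid at this place on the ring would bring a clear change in growth inhibition.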